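This account rests on a few compounds, and the source may have more. Where it says the series, first, only, none or still open, it means among the compounds named here.

Working notes on a short oxadiazole ketone series tested in a functional assay on the whole organism (strain Wistar) for inhibition, with Rattus norvegicus as the target, with stated times of 30 min and 3 h, at a dose of 20 mg/kg by the oral route; a lower number here means less inhibition, a higher number more inhibition at the dose given (going by the name of the read-out).

Compound 1 `Cc1ccc(C(=O)CCc2nnc(-c3ccccc3Cl)o2)cc1` gives 57.3% in this assay. Compound 2 `Cc1ccc(C(=O)CCc2nnc(-c3ccc(Cl)cc3)o2)cc1` gives 81.5% in this assay. Compound 3 `Cc1ccc(C(=O)CCc2nnc(-c3ccccc3Cl)o2)c(C)c1` gives 60.5% in this assay.

Two single changes connect these three. Compound 1 and compound 2 differ by 4-chlorophenyl in place of 2-chlorophenyl on an aromatic carbon, and this assay moves a number 24.2 percentage points higher from compound 1 to compound 2 (beyond the scatter). Compound 1 and compound 3 differ by methyl in place of hydrogen on an aromatic carbon, and this assay moves a number 3.2 percentage points higher from compound 1 to compound 3 (within the scatter), so compound 1 and compound 3 are indistinguishable here. Compound 3 stands below compound 2, a gap beyond the scatter, and close to compound 1.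

Compound 4 `Cc1ccc(C(=O)CCc2nnc(-c3ccc(Cl)cc3)o2)c(C)c1` has not yet been measured. It differs from compound 3 by 4-chlorophenyl in place of 2-chlorophenyl on an aromatic carbon, which is the same change already seen from compound 1 to compound 2, with the same surroundings at the site of the change. The cores of compound 3 and compound 4 differ from those of compound 1 and compound 2 by methyl in place of hydrogen on an aromatic carbon. Within the data shown here, the single precedent for this change is the step from compound 1 to compound 2, and that precedent carries a core in which the methyl is absent. On these data alone, whether the added methyl alters the size of the step is untested. On this basis the step from compound 3 to compound 4 in this assay is expected to be a number 20.5 percentage points higher from compound 3 to compound 4 (beyond the scatter), because compound 3 starts from 60.5% and the earlier step was a number 24.2 percentage points higher from compound 1 to compound 2 (beyond the scatter). Compound 4 is therefore estimated at 81% in this assay, with a range from 66% to 92% allowing for the untested effect of the core.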

Compound 4, a percentage reported as inhibition, in the whole organism at one dose (the size of the read-out at that dose, not a potency): 72.6%
Beside the measured number, compound 4's estimate is 8.4 percentage points above it, within the range that was stated.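

In this assay, 4-chlorophenyl in place of 2-chlorophenyl again raises the number on the methylated core, with a number 12.1 percentage points higher from compound 3 to compound 4 (beyond the scatter), so the direction of the change carries across both cores and the size of the two steps cannot be told apart: the same change on two cores in this assay, a number 24.2 percentage points higher (beyond the scatter) from compound 1 to compound 2 and a number 12.1 percentage points higher (beyond the scatter) from compound 3 to compound 4, 12.1 percentage points apart, within the scatter of two such steps

Methyl in place of hydrogen on an aromatic carbon gives a number 8.9 percentage points lower from compound 2 to compound 4 (within the scatter), and this step, like the earlier methyl step, stays inside the usual scatter, so the methyl has no demonstrated effect on the read-out with either chlorophenyl group: the same change on two cores in this assay, a number 3.2 percentage points higher (within the scatter) from compound 1 to compound 3 and a number 8.9 percentage points lower (within the scatter) from compound 2 to compound 4, 12.1 percentage points apart, within the scatter of two such steps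

This does not show that the two chlorophenyl steps are equal, since a gap within the scatter leaves a real difference neither proven nor excluded, and two cores say nothing about how the change would behave on any further core.

The compounds shown leave open whether the gain tracks chlorine itself or would persist with fluorine, methoxy or an amine in its place on the phenyl ring, and whether it survives a longer chain between the carbonyl and the five-membered ring. Each compound is also read at one dose only, so the numbers describe the size of the effect at that dose and leave relative potency open.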